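One group exchanged on the core of compound 1

This account rests on a few compounds, and the source may have more. Where it says the series, first, only, none or still open, it means among the compounds named here.

Compound 1 `O=C1CCCN1c1cnc(NCc2c(F)ccc3c2CCO3)n2cnnc12` carries a 2-oxopyrrolidin-1-yl group on its fused core. In a physicochemical assay for lipophilicity, using the shake flask method, in phosphate buffer, measured as octanol-water partition, with a stated time of 30 min, at pH 7.4 (a higher number here means a more lipophilic compound, a lower number a more polar compound), compound 1 gives 1.3. Among the measured compounds shown here, that is the lowest of the three numbers measured so far: compound 3 `Cn1nccc1-c1cnc(NCc2c(F)ccc3c2CCO3)c2cn[nH]c(=O)c12` gives 2.6, and compound 2 `CNC(=O)c1ccc(-c2cnc(NCc3c(F)ccc4c3CCO4)c3cn[nH]c(=O)c23)c(C)n1` gives 2.9, both beyond the scatter above compound 1. For the measured compounds named here, compound 2 and compound 3 are built on a core different from that of compound 1, and the one step measured between them, a number 0.30 log units lower from compound 2 to compound 3 (within the scatter), concerns a group at another place on that other core. Compound 4 `O=C(Nc1cnc(NCc2c(F)ccc3c2CCO3)n2cnnc12)c1cccnc1` differs from compound 1 in a single place: ((pyridin-3-yl)carbonyl)amino in place of 2-oxopyrrolidin-1-yl on an aromatic carbon. Going by the values given here, no measured step speaks to this exchange, so the expectation rests only on compound 1 and its value of 1.3. With nothing to push it far either way, the step is expected to be small, a number 0.20 log units higher from compound 1 to compound 4 (within the scatter), and may stay within the scatter. Compound 4 is therefore estimated at 1.5, with a range from 0.9 to 2.1.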

Compound 4, distribution coefficient: 2
Compound 4: the middle estimate sits 0.50 log units below what was measured; the measured number falls inside the stated range.
By their numbers in this assay, from the lowest: compound 1; then compound 4; then compounds 3 and 2 (each within the scatter of the next).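

In this assay, ((pyridin-3-yl)carbonyl)amino in place of 2-oxopyrrolidin-1-yl on an aromatic carbon of the core of compound 1 gives a number 0.70 log units higher from compound 1 to compound 4 (beyond the scatter), the only measured step at this position among the compounds shown. This shows that the number responds to a change of group here, and that a group with 9 heavy atoms and 1 hydrogen-bond donor can take the place of one with 6 heavy atoms and no donor on this core. No measurement at hand accounts for the size of this step.

With only these two groups compared at this position, the compounds leave open whether the step follows the amide hydrogen or the pyridine ring. An acetylamino or a benzoylamino group at the same place would tell these apart.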